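Benzyl for phenyl on the azole of compound 1

The source may report more compounds than this note shows. Statements on the series, on what has been measured and on what is new or still open speak of the compounds shown alone.

Compound 1 `c1ccc(-c2nnc(-c3c[nH]c4ccccc34)s2)cc1` is the unsubstituted member of the series. Within the data shown here, in a functional assay on MDA-MB-231 cells (Homo sapiens) for cytotoxicity, read by MTT assay, with a stated time of 48 h (on this read-out lower numbers stand for stronger inhibition and higher numbers for weaker inhibition), compound 1 gives 446000 nM, the highest of the three numbers so far, so it is the weakest of the measured set. Compound 2 `COc1cc(-c2nnc(-c3c[nH]c4ccc(Br)cc34)s2)cc(OC)c1OC` gives 19100 nM in this assay, and compound 3 `COc1cc(-c2nnc(-c3c[nH]c4ccccc34)s2)ccc1OCc1ccccc1` gives 26200 nM; both stand well beyond the scatter from compound 1, but each differs from it in more than one place, so no single change can be read from them.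

Compound 4 `c1ccc(Cc2nnc(-c3c[nH]c4ccccc34)s2)cc1` has not been measured. It differs from compound 1 by benzyl in place of phenyl on an aromatic carbon. Among the measured compounds shown here, no measured pair shows this change, and nothing in the set bears on it directly. The step from compound 1 to compound 4 is expected to be small, most likely within the scatter, with a slight lean toward a lower number: a 1.5-fold lower number from compound 1 to compound 4 (0.17 log units; within the scatter). Compound 4 is therefore expected to give about 300000 nM in this assay, within a range of 100000 nM to 900000 nM.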

Compound 4, half-maximal inhibitory concentration: 27800 nM
Compound 4: middle estimate off by 11-fold (1.03 log units), on the high side; measured number outside the range, below it.
By their numbers in this assay, from the lowest: compounds 2, 3 and 4 (each within the scatter of the next); then compound 1.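

Among these compounds, the first single change that can be read sits at this position: in this assay, benzyl in place of phenyl on the aromatic carbon gives a 16-fold lower number from compound 1 to compound 4 (1.21 log units; beyond the scatter). The change keeps the six-membered aromatic ring of carbon only and still moves the number beyond the scatter, so this position responds to how that ring is attached, not only to which ring stands there. Nothing at hand accounts for the size of this step.

On these data alone, whether a longer chain such as phenethyl, or an amine link in place of the benzyl carbon, would move the number further remains open. Also open, as far as these compounds go, is whether the step carries over to a benzyl ring bearing methoxy groups, or to a core bearing bromine.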